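Hydroxy in place of chloro on the shared core

The source may hold more compounds than are shown below. What is called first, only, known or untested is meant among the compounds shown, and "the series" means these compounds.

In a functional assay on HCT-116 cells (Homo sapiens) for antiproliferative activity, read by MTT assay, with a stated time of 48 h (a higher number here means a weaker inhibitor, a lower number a stronger inhibitor), compound 1 (`COc1ccc(N(C)c2cc(C)nc(C)n2)cc1F`), the fluoro member, gives 584 nM and compound 2 (`COc1ccc(N(C)c2cc(C)nc(C)n2)cc1Cl`), the chloro member, gives 1190 nM as the higher of the two numbers. For the measured compounds named here, the only measured step is a 2.0-fold higher number from compound 1 to compound 2 (0.31 log units; beyond the scatter) for chloro in place of fluoro on an aromatic carbon, a modest change.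

Compound 3 (`COc1ccc(N(C)c2cc(C)nc(C)n2)cc1O`) has not yet been measured in this assay and carries hydroxy in place of chloro on an aromatic carbon, ortho to a methoxy group: hydroxy in place of chloro on an aromatic carbon is the counted change. Going by the values given here, no measured step involves a hydroxy group, so a 2.0-fold higher number from compound 1 to compound 2 (0.31 log units; beyond the scatter) is only an indirect guide to the likely size, and it says nothing firm on direction. A modest move away from the chloro value is the working expectation, with a wide margin that allows for no gain at all. The expected change is a 1.6-fold lower number from compound 2 to compound 3 (0.20 log units; within the scatter) on this estimate. Compound 3 is estimated at 750 nM with an expected range of 220 nM to 2600 nM in this read-out.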

Compound 3, half-maximal inhibitory concentration: 126 nM
Estimate against measurement, compound 3: 6.0-fold (0.77 log units) above; measured number below the stated range.
By their numbers in this assay, from the lowest: compound 3; then compound 1; then compound 2.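

In this assay, this position, ortho to a methoxy group, responds more strongly to a change of substituent than the two halogen members showed: hydroxy in place of chloro gives a 9.4-fold lower number from compound 2 to compound 3 (0.98 log units; beyond the scatter), a larger step than a 2.0-fold higher number from compound 1 to compound 2 (0.31 log units; beyond the scatter). Hydroxy in place of fluoro runs the same way, with a 4.6-fold lower number from compound 1 to compound 3 (0.67 log units; beyond the scatter), so the hydroxy member holds the lowest number of the three, beyond the scatter from both halogen members. The change adds one hydrogen-bond donor and one hydrogen-bond acceptor relative to chloro, but that count is only a description, and nothing at hand explains the size of the step.

As far as these compounds go, whether the lower number belongs to hydroxy alone or extends to other groups at this place, such as an amine or a carboxylic acid, remains open. Only this one place varies across the three compounds, so it is also unknown whether the hydroxy step would hold with a different group elsewhere on the shared core, or in any read-out other than this assay.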